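Replacing the tert-butoxy cap of compound 1 with a dimethylamino chain

The source may report more compounds than this note shows. Statements on the series, on what has been measured and on what is new or still open speak of the compounds shown alone.

Measured so far:
compound 1 `CC(C)(C)OC(=O)N1CCC[C@H]1C(=O)N1CCC(NS(=O)(=O)c2cc(S(=O)(=O)c3ccccc3)ccc2C(F)(F)F)CC1`: 60 nM
compound 2 `O=C1CC[C@@H](C(=O)N2CCC(NS(=O)(=O)c3cc(S(=O)(=O)c4ccccc4)ccc3C(F)(F)F)CC2)N1`: 240 nM
compound 3 `CC(C)(C)CC(=O)N1CCC[C@H]1C(=O)N1CCC(NS(=O)(=O)c2cc(S(=O)(=O)c3ccccc3)ccc2C(F)(F)F)CC1`: 120 nM

In a functional assay on U2OS cells for antagonist activity at proto-oncogene Wnt-3 (Homo sapiens), read by a luciferase reporter, with a stated time of 18 h (on this read-out lower numbers stand for an effect already at smaller amounts and higher numbers for an effect only at larger amounts of compound), compound 1 holds the lowest number of the three; compound 3 sits within the scatter of it, while compound 2 lies a 4.0-fold higher number from compound 1 to compound 2 (0.60 log units; beyond the scatter). Compound 4 `CN(C)CC(=O)N1CCC[C@H]1C(=O)N1CCC(NS(=O)(=O)c2cc(S(=O)(=O)c3ccccc3)ccc2C(F)(F)F)CC1` differs from compound 1 by (dimethylamino)methyl in place of tert-butoxy on a carbonyl carbon. Going by the values given here, the closest precedent is the swap at the same carbonyl carbon that gives compound 3, which moved the number only a 2.0-fold higher number from compound 1 to compound 3 (0.30 log units; within the scatter). The larger shift seen for compound 2 came with a change to the ring itself and so speaks less directly to this step. A small change is therefore expected, a 1.7-fold higher number from compound 1 to compound 4 (0.22 log units; within the scatter), with compound 4 estimated at 100 nM (range 40 nM to 250 nM).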

Compound 4, half-maximal effective concentration: 310 nM
For compound 4 the middle estimate is 3.1-fold (0.49 log units) below the measured one, outside the stated range (above it).
By their numbers in this assay, from the lowest: compounds 1, 3, 2 and 4 (each within the scatter of the next, the first and the last beyond it).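

In this assay, the group on this carbonyl carbon matters more than compound 3 suggested: the dimethylamino chain costs clearly more (a 5.2-fold higher number from compound 1 to compound 4 (0.71 log units; beyond the scatter)), and exchanging only the tert-butyl end of the chain for dimethylamino also gives a step beyond the scatter (a 2.6-fold higher number from compound 3 to compound 4 (0.41 log units; beyond the scatter)). The end of the chain therefore counts, and the result lands within the scatter of compound 2 (a 1.3-fold higher number from compound 2 to compound 4 (0.11 log units; within the scatter)). Nothing measured here accounts for this shift.

Going by these compounds, whether a diethylamino group, a longer chain before the amine, or a carboxylic acid would track compound 3 or compound 4 remains open.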